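Fluoro to methoxy on compound 2

The compounds below may be only part of what the source reports. "The series", "measured", "known", "first", "only" and "open" are said of these compounds alone.

Within the data shown here, in a functional assay on MDA-MB-231 cells (Homo sapiens) for cytotoxicity, read by MTT assay, with a stated time of 72 h (a lower number here means a stronger inhibitor, a higher number a weaker inhibitor), two compounds have numbers so far. Compound 1 (`Nn1c(SCc2ccccc2[N+](=O)[O-])nnc1-c1c[nH]c2ccccc12`) gives 9520 nM in this read-out. Compound 2 (`Nn1c(SCc2ccc(F)cc2)nnc1-c1c[nH]c2ccccc12`) gives 1350 nM and so holds the lower of the two numbers, with a gap beyond the usual scatter. These two do not differ in one place only, so their gap does not measure any single change. Compound 3 (`COc1ccc(CSc2nnc(-c3c[nH]c4ccccc34)n2N)cc1`) has methoxy in place of fluoro on an aromatic carbon, para to a large group: methoxy in place of fluoro on an aromatic carbon is the whole change. Among the measured compounds shown here, no measured step of this kind exists, so the expectation is loose. In this assay a small rise in the number is expected, not clearly beyond the scatter, and the estimate starts from compound 2 at 1350 nM as the reference. The estimated change is a 1.9-fold higher number from compound 2 to compound 3 (0.27 log units; within the scatter) in size. For compound 3 the expected value is 2500 nM with an estimated range of 700 nM to 8000 nM as the span.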

Compound 3, half-maximal inhibitory concentration: 1700 nM
Compound 3: the middle estimate sits 1.5-fold (0.17 log units) above what was measured; low and high end bracket the measured number.
By their numbers in this assay, from the lowest: compounds 2 and 3 (each within the scatter of the next); then compound 1.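

In this assay, putting methoxy in place of fluoro on an aromatic carbon, para to a large group, gives a 1.3-fold higher number from compound 2 to compound 3 (0.10 log units; within the scatter). Among these compounds, this is the first comparison that differs in one place only, and it shows that this position accepts 4-methoxyphenyl in place of 4-fluorophenyl, with its extra heavy atom and hydrogen-bond acceptor, without a change that can be read beyond the scatter. No available evidence bears on why these two groups read alike.

As far as these compounds go, whether this holds beyond fluoro and methoxy remains open: an amine, a carboxylic acid or a longer chain such as butoxy on the same aromatic carbon could still move the number beyond the scatter. The gap separating compound 1 from the other two also stays unassigned, since compound 1 differs from each of them in more than one place.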